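Estimating clearance for an imidazolyl analogue of compound 3

A few compounds are considered here, and "the series" means these few. Any claim that something is new, unique, unknown or untested is made for them only; others in the source may bear on it.

Compound 1 `CC(O)c1nc([C@@H](O)[C@H](O)[C@H](O)CO)c[nH]1`: 16.4 mL/min/kg
Compound 2 `CN(C)C(=O)c1nc([C@@H](O)[C@H](O)[C@H](O)CO)c[nH]1`: 11.3 mL/min/kg
Compound 3 `OC[C@@H](O)[C@@H](O)[C@H](O)c1c[nH]c(-c2cocn2)n1`: 16.6 mL/min/kg

In an in vivo ADME assay on the whole organism (strain 129/SvEvBrd x C57BL/6) for pharmacokinetics, with Mus musculus as the target, at a dose of 1 mg/kg by the intravenous route (on this read-out lower numbers stand for slow clearance and higher numbers for fast clearance), compound 3 is not separated from the other two compounds by more than the scatter. Compound 4 `OC[C@@H](O)[C@@H](O)[C@H](O)c1c[nH]c(-c2ncc[nH]2)n1` carries 1H-imidazol-2-yl in place of 1,3-oxazol-4-yl on an aromatic carbon. The three measured steps swap the group on this same carbon, and all are small: a 1.5-fold lower number from compound 1 to compound 2 (0.16 log units; within the scatter), a 1.0-fold higher number from compound 1 to compound 3 (0.01 log units; within the scatter) and a 1.5-fold higher number from compound 2 to compound 3 (0.17 log units; within the scatter). These three compounds give no sign of a large effect at this place, so no step beyond the scatter is expected here. The estimated step is a 1.1-fold lower number from compound 3 to compound 4 (0.04 log units; within the scatter). The expected value for compound 4 is 15 mL/min/kg, with an estimated range from 8 mL/min/kg to 28 mL/min/kg.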

Compound 4, clearance: 31.5 mL/min/kg
Estimate against measurement, compound 4: 2.1-fold (0.32 log units) below, and the stated range ends below it.
By their numbers in this assay, from the lowest: compounds 2, 1, 3 and 4 (each within the scatter of the next, the first and the last beyond it).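

In this assay, within the data shown here, the swap to 1H-imidazol-2-yl gives the only step on this carbon that lies beyond the scatter (a 2.8-fold higher number from compound 2 to compound 4 (0.45 log units; beyond the scatter)), a modest one seen only against dimethylcarbamoyl. The other two steps stay within the scatter (a 1.9-fold higher number from compound 3 to compound 4 (0.28 log units; within the scatter); a 1.9-fold higher number from compound 1 to compound 4 (0.28 log units; within the scatter)), so the group on this carbon can matter, but only the comparison with compound 2 shows it. Nothing measured here explains the step. The compounds shown leave open how a primary amine or a carboxylic acid on this carbon would behave.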